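The source may report more compounds than this note shows. Statements on the series, on what has been measured and on what is new or still open speak of the compounds shown alone.

Going by the values given here, compound 1 `COc1cc(C(=O)NS(=O)(=O)c2ccccc2)ccc1Cn1ncc2ccc(NC(=O)CC3CCCC3)cc21` gives 10.5 in a functional assay (trachea) for antagonist activity, with Cavia porcellus as the target (a higher number here means a more potent compound, by a factor of ten per unit of this negative logarithm, a lower number a less potent compound), the highest of the three numbers measured so far. Compound 2 `COc1cc(C(=O)NS(=O)(=O)c2cccs2)ccc1Cn1ccc2ccc(NC(=O)CC3CCCC3)cc21` gives 9.6 in this assay, and compound 3 `CCCCC(CC)C(=O)Nc1ccc2ccn(Cc3ccc(C(=O)NS(=O)(=O)c4ccc(OC)cc4)cc3OC)c2c1` gives 7.4; both stand below compound 1 by more than the scatter. Compound 4 `CCCCOC(=O)Nc1ccc2cnn(Cc3ccc(C(=O)NS(=O)(=O)c4ccccc4)cc3OC)c2c1` has not yet been measured in this assay. It differs from compound 1 in one place: butoxy in place of cyclopentylmethyl on a carbonyl carbon. Among the compounds with values here, no measured pair shows this change, so its size is open. The expected step is a number 0.50 log units lower from compound 1 to compound 4 (beyond the scatter), a small loss that may sit within or just beyond the scatter. Compound 4 is therefore estimated at 10, with a range from 9.2 to 10.8.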

Compound 4, negative logarithm of the antagonist equilibrium constant: 9.2
Compound 4: the middle estimate sits 0.80 log units above what was measured; the measured number falls inside the stated range.
By their numbers in this assay, from the lowest: compound 3; then compound 4; then compound 2; then compound 1.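

Going by these compounds alone, at the carbonyl carbon, the change from cyclopentylmethyl to butoxy gives the first single-place step in this assay: a number 1.30 log units lower from compound 1 to compound 4 (beyond the scatter). This position is therefore not indifferent to the group it carries, although compound 4 still reaches 9.2 in this assay. No measurement at hand accounts for the size of this loss. As far as these compounds go, the ring leaves and the oxygen enters in the same step, so their separate shares remain open. A pentyl chain or a cyclopentylmethoxy group on the same carbonyl carbon would separate the two.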